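From methoxy to hydroxy in compound 4

The source may report more compounds than this note shows. Statements on the series, on what has been measured and on what is new or still open speak of the compounds shown alone.

In a functional assay on cells (Breast carcinoma cell, Homo sapiens) for cytotoxicity, read by sulforhodamine B assay, with a stated time of 48 h (a lower number here means a stronger inhibitor of growth, a higher number a weaker inhibitor of growth), compound 1 (`COc1cc2c(cc1C)NC(=O)/C2=C/c1c(OC)nc2sc(C)cn12`) at 50900 nM and compound 2 (`O=C1Nc2ccccc2C1=Cc1c(-c2ccncc2)nc2sccn12`) at 67400 nM both lie within the scatter of compound 3 (`COc1ccc2c(c1)/C(=C\c1c(OC)nc3sc(C)cn13)C(=O)N2`) at 61300 nM and compound 3 therefore holds no clear rank among them. Compound 4 (`COc1nc2sc(C)cn2c1/C=C1/C(=O)Nc2ccc(O)cc21`) differs from compound 3 as hydrogen in place of methyl on an oxygen on an aromatic ring shows: methoxy to hydroxy, hydrogen in place of methyl on an oxygen on an aromatic ring. Within the data shown here, no measured step makes this exact change. The closest one (a 1.2-fold higher number from compound 1 to compound 3 (0.08 log units; within the scatter)) puts hydrogen in place of methyl on an aromatic carbon instead and stays within the scatter. In this assay no step beyond the scatter is therefore expected (a 1.1-fold lower number from compound 3 to compound 4 (0.05 log units; within the scatter)). The expected value for compound 4 is 55000 nM (estimated range 25000 nM to 100000 nM).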

Compound 4, concentration for total growth inhibition: 66200 nM
Compound 4: middle estimate off by 1.2-fold (0.08 log units), on the low side; the range from low to high includes it.
By their numbers in this assay, from the lowest: compounds 1, 3, 4 and 2 (each within the scatter of the next).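

In this assay, the swap of methoxy for hydroxy (a 1.1-fold higher number from compound 3 to compound 4 (0.03 log units; within the scatter)) is the first step shown that alters this oxygen on an aromatic ring rather than an aromatic carbon. Losing that methyl leaves compound 3 and compound 4 indistinguishable, so this oxygen's methyl is not needed to keep the growth inhibition seen here. No measurement available here accounts for this result. Still open, as far as these compounds go, is whether an amine in place of the hydroxy, or a longer chain such as ethoxy on this oxygen, would move the number beyond the scatter.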